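A few compounds are considered here, and "the series" means these few. Any claim that something is new, unique, unknown or untested is made for them only; others in the source may bear on it.

Compound 2 `CCCCCCCCCC(=O)N[C@H]1CNC1=O` belongs to a small group of three measured compounds. In an assay on HEK293 cells for inhibition of N-acylethanolamine-hydrolyzing acid amidase (Homo sapiens), read by fluorescence, with stated times of 10 min and 30 min (on this read-out higher numbers stand for weaker inhibition and lower numbers for stronger inhibition), compound 2 gives 240 nM. Compound 1 `CC(C)(C)[C@@H]1OC(=O)[C@H]1NC(=O)OCCCCCc1ccccc1`, built on a different core, gives 234 nM in this assay, a number that lies within the usual scatter of that of compound 2, so the two cannot be told apart. Within the data shown here, compound 3 `CCCCCCCCCCC(=O)N[C@H]1CNC1=O` shares the core of compound 2; in this assay compound 3 gives 100 nM, and the step of a 2.4-fold lower number from compound 2 to compound 3 (0.38 log units; beyond the scatter) is the one change in this set that moves the number beyond the scatter.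

Compound 4 `O=C(CCCCCCC1CCCCC1)N[C@H]1CNC1=O` has not yet been measured. It differs from compound 2 by cyclohexyl in place of propyl on a saturated chain carbon, six bonds along the chain from a carbonyl carbon. Among the measured compounds shown here, the only measured step that bears on it is a 2.4-fold lower number from compound 2 to compound 3 (0.38 log units; beyond the scatter), where adding carbon at the far end of the chain lowered the number. Compound 4 adds carbon at a similar place, so a lowering of comparable size is expected, a 2.2-fold lower number from compound 2 to compound 4 (0.34 log units; beyond the scatter). Compound 4 is therefore estimated to give 110 nM in this assay, with a likely range from 50 nM to 250 nM.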

Compound 4, half-maximal inhibitory concentration: 280 nM
The estimate for compound 4 lay 2.5-fold (0.41 log units) below the measured number; measured number outside the range, above it.
By their numbers in this assay, from the lowest: compound 3; then compounds 1, 2 and 4 (each within the scatter of the next).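

In this assay cyclohexyl in place of propyl, six bonds along the chain from a carbonyl carbon, gives a 1.2-fold higher number from compound 2 to compound 4 (0.07 log units; within the scatter) and so shows that adding carbon here does not by itself lower the number. Against the straight chain of compound 3, cyclohexyl in place of butyl at the same place gives a 2.8-fold higher number from compound 3 to compound 4 (0.45 log units; beyond the scatter) and so shows that the gain seen with compound 3 does not carry over to this ring. Nothing available explains why the straight chain and the ring part ways here.

The compounds shown cannot say whether a phenyl group or a cyclopentyl group in place of cyclohexyl would follow compound 3 or compound 4. They also leave open whether a longer straight chain would lower the number further.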